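Chloro for Trifluoromethyl on the Urea Aryl Ring

This account rests on a few compounds, and the source may have more. Where it says the series, first, only, none or still open, it means among the compounds named here.

For the measured compounds named here, compound 2 `COc1cc2cc(Oc3ccc(NC(=O)Nc4ccc(Cl)c(C(F)(F)F)c4)cc3)c(C)nc2cc1OC` stands lowest of the two numbers so far: in a functional assay on A498 cells (Homo sapiens) for inhibition, read by sulforhodamine B assay, with a stated time of 48 h, tested at 10 uM (a lower number here means a stronger effect, a higher number a weaker effect of the compound at the concentration tested), compound 2 gives 10.5%, while compound 1 `COc1cc2cc(Oc3ccc(NC(=O)Nc4ccc(C(F)(F)F)cc4)cc3)c(C)nc2cc1OC` gives 90.5%. Going by the values given here, the only step recorded, a number 80 percentage points lower from compound 1 to compound 2 (beyond the scatter), concerns a different change and bears on compound 3 only in sharing the 4-chloro substituent. Compound 3 `COc1cc2cc(Oc3ccc(NC(=O)Nc4ccc(Cl)c(Cl)c4)cc3)c(C)nc2cc1OC` differs from compound 2 by chloro in place of trifluoromethyl on an aromatic carbon. Among the compounds with values here, with no direct precedent, a step of a number 14.5 percentage points higher from compound 2 to compound 3 (beyond the scatter) toward a weaker effect is expected, and compound 3 is estimated at 25%, within 5% to 60%.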

Compound 3, a percentage reported as activity, at one concentration (the size of the read-out at that concentration, not a potency): 35.8%
Compound 3: middle estimate off by 10.8 percentage points, on the low side, and the stated range covers the measured number.
By their numbers in this assay, from the lowest: compound 2; then compound 3; then compound 1.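

In this assay, the position ortho to a chloro group tolerates chloro in place of trifluoromethyl only in part: a number 25.3 percentage points higher from compound 2 to compound 3 (beyond the scatter) is a modest loss of effect. The 3,4-dichlorophenyl ring still retains much of the gain over 4-(trifluoromethyl)phenyl, with a number 54.7 percentage points lower from compound 1 to compound 3 (beyond the scatter) a large step. Nothing available explains the difference between chloro and trifluoromethyl here. Open, as far as these compounds go, is how a methyl, a methoxy, a nitrile or an amine would compare on this same carbon. Also open, from the compounds shown here alone, is whether trifluoromethyl keeps its edge over chloro when the neighbouring chloro group is replaced by fluoro.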